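Ester to Carbamate: Expecting the Number for Compound 3

The source may report more compounds than this note shows. Statements on the series, on what has been measured and on what is new or still open speak of the compounds shown alone.

Measured so far:
Compound 1, `CCCCCCCC(=O)OCC1CN(C(=O)c2cc(OC)c(OC)c(OC)c2)CCN1C(=O)c1cc(OC)c(OC)c(OC)c1`: 310 nM
Compound 2, `COc1cc(C(=O)N2CCN(C(=O)c3cc(OC)c(OC)c(OC)c3)C(COC(=O)C3CCCCC3)C2)cc(OC)c1OC`: 290 nM

In a functional assay (Oryctolagus cuniculus) for inhibition of platelet-activating factor receptor (Cavia porcellus) (on this read-out higher numbers stand for weaker inhibition and lower numbers for stronger inhibition), compound 2 gives 290 nM, and compound 1 stands within the scatter of it, as a 1.1-fold lower number from compound 1 to compound 2 (0.03 log units; within the scatter) shows. Compound 3, `CCCCCCCCNC(=O)OCC1CN(C(=O)c2cc(OC)c(OC)c(OC)c2)CCN1C(=O)c1cc(OC)c(OC)c(OC)c1`, differs from compound 2 in one place: octylamino in place of cyclohexyl on a carbonyl carbon. For the measured compounds named here, the single measured step that bears on this change, a 1.1-fold lower number from compound 1 to compound 2 (0.03 log units; within the scatter), exchanged a chain for a ring without moving the number beyond the scatter. Compound 3 returns to a chain, so the expected step of a 1.0-fold higher number from compound 2 to compound 3 (0.01 log units; within the scatter) stays within the scatter. Compound 3 is therefore estimated at 300 nM, between 120 nM and 750 nM.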

Compound 3, half-maximal inhibitory concentration: 370 nM
Compound 3: middle estimate off by 1.2-fold (0.09 log units), on the low side; the range from low to high includes it.
By their numbers in this assay, from the lowest: compounds 2, 1 and 3 (each within the scatter of the next).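

In this assay, octylamino brings a nitrogen and a hydrogen-bond donor to the carbonyl carbon, where cyclohexyl and heptyl have neither. Even so, the result is a 1.3-fold higher number from compound 2 to compound 3 (0.11 log units; within the scatter) and a 1.2-fold higher number from compound 1 to compound 3 (0.08 log units; within the scatter), so both steps stay within the scatter. This place therefore accepts the ester-to-carbamate change without a readable shift in the number, and nothing available here explains why.

Still open, on these data alone, is whether a carboxylic acid or a basic amine on this chain would move the number. A much shorter chain, such as methylamino, also remains untested in the compounds shown.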